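Swapping an acetyl for a tolylsulfonyl on the aniline nitrogen

A few compounds are considered here, and "the series" means these few. Any claim that something is new, unique, unknown or untested is made for them only; others in the source may bear on it.

Compound 1 `Nc1cc(NS(=O)(=O)c2ccccc2)cc(-c2cnc3[nH]cc(-c4ccncc4)c3c2)c1` gives 9.4 nM in an assay on isolated protein for inhibition of high affinity nerve growth factor receptor (Homo sapiens), read by 33P incorporation; a lower number here means a stronger inhibitor, a higher number a weaker inhibitor.
Compound 2 `CC(=O)Nc1cc(N)cc(-c2cnc3[nH]cc(-c4ccncc4)c3c2)c1` gives 5.41 nM in this assay.

Going by the values given here, compound 2 shows the smaller of the two numbers measured so far, but compound 1 lies within the scatter of it, so the two cannot be told apart. Compound 3 `Cc1ccc(S(=O)(=O)Nc2cc(N)cc(-c3cnc4[nH]cc(-c5ccncc5)c4c3)c2)cc1` differs from compound 2 by (4-methylphenyl)sulfonyl in place of acetyl on a nitrogen on an aromatic ring. Among the compounds with values here, only one measured step bears on this exchange: a 1.7-fold lower number from compound 1 to compound 2 (0.24 log units; within the scatter), a step that stays inside the scatter. Within the data shown here, compound 3 reverses that exchange, with the difference that the group entering is a (4-methylphenyl)sulfonyl rather than a phenylsulfonyl; no measured pair shows what that methyl does. The expected step is therefore a 1.7-fold higher number from compound 2 to compound 3 (0.22 log units; within the scatter), landing near compound 1 rather than marking a real change. Compound 3 is estimated at 9 nM in this assay, with a range from 4 nM to 22 nM.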

Compound 3, half-maximal inhibitory concentration: 4.62 nM
The estimate for compound 3 lay 1.9-fold (0.29 log units) above the measured number, within the range that was stated.
By their numbers in this assay, from the lowest: compounds 3, 2 and 1 (each within the scatter of the next, the first and the last beyond it).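

On this nitrogen on an aromatic ring, a far bigger group fits without any clear loss: (4-methylphenyl)sulfonyl brings 10 heavy atoms and an aromatic ring where acetyl has 3 heavy atoms and no ring, yet this assay shows a 1.2-fold lower number from compound 2 to compound 3 (0.07 log units; within the scatter) and so cannot tell the two compounds apart. Going by these compounds alone, the only step here to clear the scatter, and only modestly, is methyl in place of hydrogen on an aromatic carbon, which gives a 2.0-fold lower number from compound 1 to compound 3 (0.31 log units; beyond the scatter) and is the first sign that a change this small can register. No measurement here accounts for either step.

From the compounds shown here alone, it remains open how a simple alkyl sulfonyl such as methylsulfonyl, or a longer chain on the carbonyl, would behave on this nitrogen. Also open, going by these compounds, is what a carboxylic acid or a basic amine at the end of such a chain would do.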